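From Ethyl to tert-Butyl on the Shared Core

This account rests on a few compounds, and the source may have more. Where it says the series, first, only, none or still open, it means among the compounds named here.

Three compounds have been measured in a functional assay on XF498 cells (Homo sapiens) for antiproliferative activity, read by MTT assay, with a stated time of 96 h; on this read-out higher numbers stand for weaker inhibition and lower numbers for stronger inhibition:
compound 1, `CN(C)c1ccc(N2C(=O)NC3(CSC4=C3C(=O)c3ncccc3C4=O)C2=O)cc1`, gives 800 nM;
compound 2, `O=C1NC(=O)C2(CSC3=C2C(=O)c2ncccc2C3=O)N1`, gives 3120 nM;
compound 3, `CCc1ccc(N2C(=O)NC3(CSC4=C3C(=O)c3ncccc3C4=O)C2=O)cc1`, gives 1200 nM.

Compound 3 stands second highest of the three numbers. Its nearest neighbour is compound 1, with a 1.5-fold higher number from compound 1 to compound 3 (0.18 log units; within the scatter), and its furthest is compound 2, with a 2.6-fold lower number from compound 2 to compound 3 (0.41 log units; beyond the scatter).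

Compound 4, `CC(C)(C)c1ccc(N2C(=O)NC3(CSC4=C3C(=O)c3ncccc3C4=O)C2=O)cc1`, differs from compound 3 in one place: tert-butyl in place of ethyl on an aromatic carbon. Among the compounds with values here, only one measured step touches the same spot, a 1.5-fold higher number from compound 1 to compound 3 (0.18 log units; within the scatter), and it stayed within the scatter. The larger steps, a 3.9-fold higher number from compound 1 to compound 2 (0.59 log units; beyond the scatter) and a 2.6-fold lower number from compound 2 to compound 3 (0.41 log units; beyond the scatter), came from removing or adding the whole aromatic group, not from changing the group on it. Compound 4 is therefore expected to show a 1.1-fold higher number from compound 3 to compound 4 (0.03 log units; within the scatter), nothing beyond the scatter. The estimate for compound 4 is 1300 nM, expected to fall between 500 nM and 3500 nM.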

Compound 4, half-maximal inhibitory concentration: 850 nM
For compound 4 the middle estimate is 1.5-fold (0.18 log units) above the measured one, within the range that was stated.
By their numbers in this assay, from the lowest: compounds 1, 4 and 3 (each within the scatter of the next); then compound 2.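

In this assay, tert-butyl on this aromatic carbon gives a 1.4-fold lower number from compound 3 to compound 4 (0.15 log units; within the scatter) and, set against dimethylamino, a 1.1-fold higher number from compound 1 to compound 4 (0.03 log units; within the scatter) so the three groups seen here cannot be told apart, even though the new group is the bulkiest by heavy-atom count. The whole 4-(tert-butyl)phenyl group still matters on the amide-type nitrogen, with a 3.7-fold lower number from compound 2 to compound 4 (0.56 log units; beyond the scatter) in line with the other two aromatic compounds. No measurement here offers a reason for this flat result.

As far as these compounds go, whether a carboxylic acid, a primary amine or a longer chain such as n-hexyl on this carbon would also leave the number unchanged remains open.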